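The compounds below may be only part of what the source reports. "The series", "measured", "known", "first", "only" and "open" are said of these compounds alone.

Working notes on the series. Compound 1 `Fc1ccc(-c2nn3c(NC4CCCC4)cccc3c2-c2ccsc2)cc1` has no result in an ADME assay on Vero cells (Chlorocebus sabaeus) for cytotoxicity; on this read-out lower numbers stand for higher toxicity in this test and higher numbers for lower toxicity in this test: the entry for compound 1 reads "not determined" (no result reported). Its two measured neighbours share the same core and the same 4-fluorophenyl group and differ only in the aromatic ring on the carbon next to it. Compound 2 `Fc1ccc(-c2nn3c(NC4CCCC4)cccc3c2-c2ccncc2)cc1` gives 20000 nM in this assay. For compound 3 `Fc1ccc(-c2nn3c(NC4CCCC4)cccc3c2-c2cccnc2)cc1` this assay reports only a limit, > 40000 nM. Among the measured compounds shown here, the one computed step, an at least 2.0-fold higher number from compound 2 to compound 3 (0.30 log units; that floor lies within the scatter), rests on that limit and cannot be called a change, since the limit of > 40000 nM in this assay, at which 1 of the 3 values shown sits, marks where one of the three values sits.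

Compound 4 `Fc1ccc(-c2nn3c(NC4CCCC4)cccc3c2-c2cc[nH]n2)cc1` differs from compound 1 by 1H-pyrazol-3-yl in place of thiophen-3-yl on an aromatic carbon. Neither measured step concerns a thiophen-3-yl or a 1H-pyrazol-3-yl ring, so the two measured compounds give only the level at which this series sits in this assay, and no direction can be read off for the change from compound 1 to compound 4. Compound 4 is therefore expected to land near the level of compounds 2 and 3, with an estimated value of 30000 nM in this assay, the expected range running from 10000 nM to 80000 nM.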

Compound 4, half-maximal cytotoxic concentration: 14000 nM
Compound 4: the middle estimate sits 2.1-fold (0.33 log units) above what was measured; low and high end bracket the measured number.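

With a five-membered ring carrying a hydrogen-bond donor at this position, the number in this assay can be set against both pyridine rings. Among the compounds shown here, the exchange for pyridin-3-yl gives an at least 2.8-fold lower number from compound 3 to compound 4 (0.45 log units; beyond the scatter) and is the first step beyond the scatter, while the exchange for pyridin-4-yl gives a 1.4-fold lower number from compound 2 to compound 4 (0.15 log units; within the scatter) and so separates 1H-pyrazol-3-yl from that ring by no real difference. The first of these steps is only a floor, since compound 3 stands at a limit: the limit of > 40000 nM in this assay, at which 1 of the 4 values shown sits.

The step from compound 1 cannot be read, so the thiophen-3-yl ring stays unplaced against the 1H-pyrazol-3-yl ring. Going by these compounds, whether an amine or a carboxylic acid on the ring at this position would shift the number in this assay remains open.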